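The source may hold more compounds than are shown below. What is called first, only, known or untested is meant among the compounds shown, and "the series" means these compounds.

Measured compounds:
- Compound 1, `COc1cc(-c2nn(-c3cccc(NC(=O)c4cccc(C(F)(F)F)c4)c3)cc2-c2ccncc2)ccc1Cl`; in a functional assay on A498 cells (Homo sapiens) for inhibition, read by sulforhodamine B assay, with a stated time of 48 h (a higher number here means that more compound is tolerated, a lower number that less compound is tolerated), compound 1 gives > 50000 nM, which is a limit of the assay rather than a number.
- Compound 2, `COc1cc(-c2nn(-c3cccc(NC(=O)Nc4cccc(C(F)(F)F)c4)c3)cc2-c2ccncc2)ccc1Cl`; in this assay compound 2 gives > 50000 nM, again a limit and not a number.

Within the data shown here, compound 2 therefore stands only at a limit, and the one other value shown is a limit as well, so its position relative to compound 1 cannot be read: a step that the two limits leave unreadable from compound 1 to compound 2.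

Compound 3, `COc1cc(-c2nn(-c3cccc(NC(=O)c4ccc(Cl)c(C(F)(F)F)c4)c3)cc2-c2ccncc2)ccc1Cl`, has not yet been measured. It differs from compound 2 in a single place: 4-chloro-3-(trifluoromethyl)phenyl in place of (3-(trifluoromethyl)phenyl)amino on a carbonyl carbon. Among the measured compounds shown here, the only measured step, the one from compound 1 to compound 2, bears on the same carbonyl carbon, but it is unreadable, and the sole evidence is that (the limit of > 50000 nM in this assay, at which 2 of the 2 values shown sit). No readable step points to any change in this assay, so the expected step in this assay is none beyond the scatter: a step that the limit leaves unreadable from compound 2 to compound 3.

On that basis compound 3 is expected to give about 60000 nM in this assay, with a range from 30000 nM to 150000 nM, and most probably the result will again be reported only as a limit.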

Compound 3, concentration lethal to 50% of the cells: > 32500 nM
Compound 3: no number, only a limit; the forecaster's own chance of this, stated with the estimate: 80%; the middle value is on the limit's open side.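

In this assay compound 3 gives > 32500 nM, which is again a limit and not a number. Among these compounds, since compound 1, compound 2 and compound 3 all stand only at limits, no step among them can be read. From the compounds shown here alone, what stays open is whether the urea, the amide or the added chloro changes cell killing at all.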